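Dimethylsulfamoylethyl in Place of Sulfamoylamino on the Core

The source may hold more compounds than are shown below. What is called first, only, known or untested is meant among the compounds shown, and "the series" means these compounds.

Of the compounds shown here, three sharing one core have been measured in an assay on HeLa cells for inhibition of Indoleamine 2,3-dioxygenase 1 (Homo sapiens), read by spectrophotometry, with a stated time of 24 h; a higher number here means that more compound is needed for the effect, a lower number that less compound is needed. Compound 1, `NNc1nonc1/C(=N/O)Nc1ccc(F)c(Br)c1`, gives 556 nM. Compound 2, `NS(=O)(=O)NNc1nonc1/C(=N/O)Nc1ccc(F)c(Br)c1`, gives 101 nM and stands second highest of the three numbers, with a 5.5-fold lower number from compound 1 to compound 2 (0.74 log units; beyond the scatter) on one side and a 9.2-fold lower number from compound 2 to compound 3 (0.96 log units; beyond the scatter) on the other. Compound 3, `NS(=O)(=O)CCNc1nonc1/C(=N/O)Nc1ccc(F)c(Br)c1`, gives 11 nM, and a 51-fold lower number from compound 1 to compound 3 (1.70 log units; beyond the scatter) is the widest span among the measured steps.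

Compound 4, `CN(C)S(=O)(=O)CCNc1nonc1/C(=N/O)Nc1ccc(F)c(Br)c1`, has not yet been measured in this assay. It differs from compound 2 in one place: 2-(dimethylsulfamoyl)ethyl in place of sulfamoylamino on a nitrogen on an aromatic ring. The step that bears most directly on it is a 9.2-fold lower number from compound 2 to compound 3 (0.96 log units; beyond the scatter), since compound 3 also carries a two-carbon chain ending in a sulfamoyl group on the same nitrogen. Within the data shown here, no measured step covers the exchange of the sulfamoyl hydrogens for two methyl groups, so the expectation rests on that single step and is widened accordingly. A lower number than compound 2 is expected, and the estimated step is a 2.9-fold lower number from compound 2 to compound 4 (0.46 log units; beyond the scatter). Compound 4 is therefore estimated at 35 nM in this assay, with an expected range from 7 nM to 180 nM.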

Compound 4, half-maximal effective concentration: 17 nM
Beside the measured number, compound 4's estimate is 2.1-fold (0.31 log units) above it; the measured number falls inside the stated range.
By their numbers in this assay, from the lowest: compounds 3 and 4 (each within the scatter of the next); then compound 2; then compound 1.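

In this assay, dimethylamino in place of amino on a sulfonyl sulfur gives a 1.5-fold higher number from compound 3 to compound 4 (0.19 log units; within the scatter), so the two hydrogen-bond donors of the sulfamoyl end in compound 3 can be replaced without a change that can be told from the scatter. The low numbers therefore do not depend on those donors: 2-(dimethylsulfamoyl)ethyl, which has none, still gives a 5.9-fold lower number from compound 2 to compound 4 (0.77 log units; beyond the scatter) and a 33-fold lower number from compound 1 to compound 4 (1.51 log units; beyond the scatter), steps that are beyond the scatter and, in the second case, large. Nothing available explains these steps or shows what the chain or its sulfonyl end does in this assay.

The compounds shown leave open how far this tolerance extends, for instance to a morpholine or a piperidine in place of dimethylamino on a sulfonyl sulfur. On these data alone, all of the ethyl-linked compounds here end in a sulfamoyl group on the same chain, so it also remains open whether a longer chain, or a carboxylic acid or an amide in place of that sulfamoyl end, would keep the number as low.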